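The compounds below may be only part of what the source reports. "The series", "measured", "known", "first", "only" and "open" are said of these compounds alone.

Compound 1 `O=C(C(c1ccccc1)c1c(-c2ccccc2)[nH]c2ccccc12)C(F)(F)F` gives 0.852 h
Compound 2 `Cc1ccc2c(C(C(=O)C(F)(F)F)c3ccccc3)c(-c3ccccc3)[nH]c2c1` gives 4.45 h

In an ADME assay on microsomes from liver (Homo sapiens) for metabolic stability, read by LC-MS, using NADPH, tested at 3 uM (on this read-out higher numbers stand for a longer-lived compound and lower numbers for a shorter-lived compound), compound 2 holds the higher of the two numbers. Compound 3 `Cc1ccc2c(C(CC(F)(F)F)c3ccccc3)c(-c3ccccc3)[nH]c2c1` differs from it thus: 2,2,2-trifluoroethyl in place of (trifluoromethyl)carbonyl on a saturated chain carbon bound to two aromatic carbons. Within the data shown here, the only measured step is a 5.2-fold higher number from compound 1 to compound 2 (0.72 log units; beyond the scatter) and it is modest though beyond the scatter. That step is methyl in place of hydrogen on an aromatic carbon, so it offers a size but no direction for this change. Among the measured compounds shown here, with compound 2 the higher of only two values at 4.45 h a modest fall is expected rather than a rise. The step expected in this assay is a 2.2-fold lower number from compound 2 to compound 3 (0.35 log units; beyond the scatter) and it should be no larger than the measured one. For compound 3 the estimate is 2 h with an expected range from 0.6 h to 6 h.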

Compound 3, half-life: 1.45 h
Beside the measured number, compound 3's estimate is 1.4-fold (0.14 log units) above it; measured number inside the range.
By their numbers in this assay, from the lowest: compounds 1 and 3 (each within the scatter of the next); then compound 2.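

In this assay, 2,2,2-trifluoroethyl in place of (trifluoromethyl)carbonyl on a saturated chain carbon bound to two aromatic carbons brings a 3.1-fold lower number from compound 2 to compound 3 (0.49 log units; beyond the scatter). Among these compounds, this is the first measured step at this place, and it gives this change a direction that the earlier methyl step could not give. No available evidence accounts for the shift. Still open, as far as these compounds go, is how other groups at this place, such as an amide or a longer chain, would compare with (trifluoromethyl)carbonyl. Also open, from the compounds shown here alone, is whether the methyl step would be of similar size with 2,2,2-trifluoroethyl present.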